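The source may hold more compounds than are shown below. What is called first, only, known or untested is meant among the compounds shown, and "the series" means these compounds.

Working notes on the chain series

All three measured compounds share one core and differ only in the saturated chain on the double-bonded nitrogen. Compound 1, `CCCC/N=C(\NC#N)Nc1cccnc1`, gives 20 mg/kg in a functional assay on the whole organism (blood, strain Wistar-Okamoto) with Rattus norvegicus as the target, with a stated time of 5 days; a lower number here means that less compound is needed, a higher number that more compound is needed for the effect. Compound 2, `CCCCC/N=C(\NC#N)Nc1cccnc1`, gives 20 mg/kg in this assay. Compound 3, `CC(C)C/N=C(\NC#N)Nc1cccnc1`, gives 20 mg/kg in this assay.

On these numbers compound 3 stands level with compound 1 and compound 2: the step of no change at the digits printed from compound 1 to compound 3 (within the scatter) and the step of no change at the digits printed from compound 2 to compound 3 (within the scatter) are both flat, as is no change at the digits printed from compound 1 to compound 2 (within the scatter). Lengthening the chain by a methyl four bonds along from the double-bonded nitrogen and exchanging propyl or butyl for isopropyl at the carbon bound to that nitrogen all left the minimum effective dose where it was.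

Compound 4 is `CC(C)CC/N=C(\NC#N)Nc1cccnc1`. The change from compound 3 is isobutyl in place of isopropyl on a saturated chain carbon bound to a double-bonded nitrogen. Going by the values given here, no measured step covers isobutyl itself, so the expectation rests on the three flat steps alone, all of which varied the same chain at the same place without moving the read-out beyond the scatter. A further one-carbon extension of a branched chain is therefore expected to behave the same way.

Compound 4 is expected to give 20 mg/kg in this assay, with a range from 10 mg/kg to 40 mg/kg. The expected step is no change at the digits printed from compound 3 to compound 4 (within the scatter), that is, no change beyond the scatter.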

Compound 4, minimum effective dose: 20 mg/kg
Beside the measured number, compound 4's estimate shows no gap at the digits printed; the range from low to high includes it.
By their numbers in this assay, from the lowest: compounds 1, 2, 3 and 4 (each within the scatter of the next).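

Isobutyl in place of isopropyl on a saturated chain carbon bound to a double-bonded nitrogen gives, in this assay, no change at the digits printed from compound 3 to compound 4 (within the scatter), so the flat picture holds for a second branched chain at this position. The other two routes to the isobutyl compound read the same, with no change at the digits printed from compound 2 to compound 4 (within the scatter) for isopropyl in place of propyl on a saturated chain carbon, two bonds along the chain from the double-bonded nitrogen, and no change at the digits printed from compound 1 to compound 4 (within the scatter) for methyl in place of hydrogen on a saturated chain carbon bound to two saturated chain carbons. Isopropyl in place of propyl now reads twice, and the two readings agree: the same change on two cores in this assay, no change at the digits printed (within the scatter) from compound 1 to compound 3 and no change at the digits printed (within the scatter) from compound 2 to compound 4, 1.0-fold (0.00 log units) apart, within the scatter of two such steps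

Every step among the four compounds lies within the scatter, so no chain shown marks a limit of what this position tolerates in the minimum effective dose. As far as these compounds go, a much longer chain such as decyl, a ring such as cyclohexyl, or a chain ending in an amine or a carboxylic acid remains open at this position.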